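The source may hold more compounds than are shown below. What is called first, only, known or untested is meant among the compounds shown, and "the series" means these compounds.

Compound 1 `CN1CCN(CCNC(=O)n2c(=O)n(Cc3ccccc3)c3ccccc32)CC1`: < 6
Compound 2 `CCCN1CCN(CCNC(=O)n2c(=O)n(C3CC3)c3ccccc32)CC1`: 7.46

Both compounds were tested in a functional assay for antagonist activity at 5-hydroxytryptamine receptor 4 (Cavia porcellus); on this read-out higher numbers stand for higher potency (the scale is a negative logarithm) and lower numbers for lower potency. For compound 1 the result is a limit of the assay rather than a number, as the limit of < 6 in this assay, at which 1 of the 2 values shown sits, shows. Compound 2 gives 7.46 in this assay, so the two values show compound 2 as the more potent of the two. For the measured compounds named here, the two compounds differ in two places at once, so no single-change step between measured compounds can be drawn.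

Compound 3 `CC(C)n1c(=O)n(C(=O)NCCN2CCN(C)CC2)c2ccccc21` has not yet been measured in this assay. It differs from compound 1 in one place: isopropyl in place of benzyl on an aromatic nitrogen. Going by the values given here, the only guide is compound 2, whose value of 7.46 is reached with a small group on that ring nitrogen. An upward step a number at least 0.80 log units higher from compound 1 to compound 3 (beyond the scatter) beyond the usual scatter is therefore expected. Compound 3 is estimated at 6.8, with a range from 6 to 7.6.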

Compound 3, negative logarithm of the antagonist equilibrium constant: < 6
Compound 3 was reported as a limit (the forecaster's own chance of this, stated with the estimate: 25%); middle value at least 0.80 log units from the limit.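

Compound 3 gives < 6 in this assay, which is a limit of the assay and not a number, and compound 1 sits at that same limit, so no step between compound 1 and compound 3 can be read: the limit of < 6 in this assay, at which 2 of the 3 values shown sit.

The compounds shown leave open whether isopropyl in place of benzyl on an aromatic nitrogen changes potency at all.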